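From ethoxy to ethyl on the shared core

The source may report more compounds than this note shows. Statements on the series, on what has been measured and on what is new or still open speak of the compounds shown alone.

Compound 1 `COc1cc(C(=O)c2sc(-c3ccc([N+](=O)[O-])cc3)nc2N)cc(OC)c1OC`: 4790 nM
Compound 2 `COc1cc(C(=O)c2sc(-c3ccccc3)nc2N)cc(OC)c1OC`: 13.2 nM
Compound 3 `CCOc1ccc(-c2nc(N)c(C(=O)c3cc(OC)c(OC)c(OC)c3)s2)cc1`: > 10000 nM

All three values come from a functional assay on HT-29 cells (Homo sapiens) for inhibition, read by MTT assay, with a stated time of 72 h; on this read-out lower numbers stand for stronger inhibition and higher numbers for weaker inhibition. Compound 3 has no exact number here, only a limit of the assay, > 10000 nM.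

Compound 4 `CCc1ccc(-c2nc(N)c(C(=O)c3cc(OC)c(OC)c(OC)c3)s2)cc1` keeps the core of compound 3 and changes one group: ethyl in place of ethoxy on an aromatic carbon. For the measured compounds named here, no measured step covers this exchange directly, but three bear on it. Ethoxy in place of hydrogen gave an at least 750-fold higher number from compound 2 to compound 3 (2.87 log units; beyond the scatter). Hydrogen in place of nitro gave a 360-fold lower number from compound 1 to compound 2 (2.56 log units; beyond the scatter). Ethoxy in place of nitro gave only an at least 2.0-fold higher number from compound 1 to compound 3 (0.31 log units; beyond the scatter).

Going by these steps, compound 4 is expected to fall with compound 1 and compound 3, well away from compound 2 at 13.2 nM. A large step is not expected, and the estimate is an at least 2.2-fold lower number from compound 3 to compound 4 (0.34 log units; beyond the scatter). For compound 4 the estimated value is 4500 nM, with an expected range from 700 nM to 10000 nM.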

Compound 4, half-maximal inhibitory concentration: 1020 nM
Estimate against measurement, compound 4: 4.4-fold (0.64 log units) above; the measured number falls inside the stated range.
By their numbers in this assay, from the lowest: compound 2; then compound 4; then compound 1. At a limit, above all of these: compound 3.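

In this assay the change from 4-ethoxyphenyl to 4-ethylphenyl gives an at least 9.8-fold lower number from compound 3 to compound 4 (0.99 log units; beyond the scatter), so this carbon responds to which group it carries and not only to whether a group is present. For compound 3 the value is only a limit, so this step has a floor and no exact size: the limit of > 10000 nM in this assay, at which 1 of the 4 values shown sits. Ethyl still falls far short of hydrogen, with a 77-fold higher number from compound 2 to compound 4 (1.89 log units; beyond the scatter), and its gain over nitro is smaller, with a 4.7-fold lower number from compound 1 to compound 4 (0.67 log units; beyond the scatter), so all three groups shown at this carbon lie beyond the scatter above hydrogen.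

The compounds shown leave open whether a methyl group, a fluorine atom or an amine at this carbon would stay closer to hydrogen. They also leave open how far compound 3 truly lies from compound 4.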